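This account rests on a few compounds, and the source may have more. Where it says the series, first, only, none or still open, it means among the compounds named here.

Compound 3, whose structure is `NS(=O)(=O)c1ccc(NC(=S)Nc2ccc3ncnc(Nc4cccc(F)c4)c3c2)cc1`, gives 30100 nM in a functional assay on A-431 cells (Homo sapiens) for antiproliferative activity, read by MTT assay, with a stated time of 72 h; on this read-out lower numbers stand for stronger inhibition and higher numbers for weaker inhibition. Among the three measured compounds it shows the highest number: compound 1 `NS(=O)(=O)c1ccc(NC(=S)Nc2ccc3ncnc(Nc4ccc(F)c(Br)c4)c3c2)cc1` gives 18200 nM, and compound 2 `NS(=O)(=O)c1ccc(NC(=S)Nc2ccc3ncnc(Nc4cccc(Cl)c4F)c3c2)cc1` gives 13100 nM. The step of a 1.7-fold higher number from compound 1 to compound 3 (0.22 log units; within the scatter) stays within the scatter, while the step of a 2.3-fold higher number from compound 2 to compound 3 (0.36 log units; beyond the scatter) lies beyond it, though only modestly.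

Compound 4 `Cc1ccc(Nc2ncnc3ccc(NC(=S)Nc4ccc(S(N)(=O)=O)cc4)cc23)cc1` differs from compound 3 by 4-methylphenyl in place of 3-fluorophenyl on a nitrogen on an aromatic ring. For the measured compounds named here, the three measured steps all concern the same site, the aryl group on that nitrogen: the steps of a 1.4-fold lower number from compound 1 to compound 2 (0.14 log units; within the scatter) and a 1.7-fold higher number from compound 1 to compound 3 (0.22 log units; within the scatter) both stay within the scatter, and only the step of a 2.3-fold higher number from compound 2 to compound 3 (0.36 log units; beyond the scatter) goes beyond it. Going by the values given here, none of them involves a methyl-bearing aryl group, so no measured step speaks directly to the change in compound 4. Given how small the earlier steps were, compound 4 is expected to land close to compound 3, with the step of a 1.1-fold lower number from compound 3 to compound 4 (0.03 log units; within the scatter) estimated as no clear change beyond the scatter. Compound 4 is therefore estimated at 28000 nM in this assay, within a range from 9000 nM to 90000 nM.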

Compound 4, half-maximal inhibitory concentration: 40000 nM
Compound 4: middle estimate off by 1.4-fold (0.15 log units), on the low side; the range from low to high includes it.
By their numbers in this assay, from the lowest: compounds 2, 1, 3 and 4 (each within the scatter of the next, the first and the last beyond it).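

For the compounds shown here, with 4-methylphenyl, the aryl group on this nitrogen carries no halogen for the first time, and in this assay this replacement of 3-fluorophenyl stays small (a 1.3-fold higher number from compound 3 to compound 4 (0.12 log units; within the scatter)). Measured against the two groups carrying two halogens, the same 4-methylphenyl group gives modest steps beyond the scatter (a 3.1-fold higher number from compound 2 to compound 4 (0.48 log units; beyond the scatter); a 2.2-fold higher number from compound 1 to compound 4 (0.34 log units; beyond the scatter)), whereas 3-fluorophenyl had gone beyond the scatter only against 3-chloro-2-fluorophenyl. Nothing given here explains these differences.

The compounds shown carry only halogens or a methyl on this aryl group, so it remains open how an amine, a carboxylic acid or a methoxy group there would read. They also leave open whether the small step would hold for 3-methylphenyl or for a longer chain such as ethyl.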